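Aryl exchange on the shared core: expectation for compound 3

A few compounds are considered here, and "the series" means these few. Any claim that something is new, unique, unknown or untested is made for them only; others in the source may bear on it.

In a functional assay on SW-620 cells (Homo sapiens) for cytotoxicity, read by sulforhodamine B assay, with a stated time of 48 h (on this read-out lower numbers stand for stronger inhibition and higher numbers for weaker inhibition), compound 1 (`C[C@H]1CC[C@@H]2[C@@H](OC(=O)[C@]23CC(c2c(Cl)cccc2Cl)=NO3)[C@]2(C)C(=O)C=C[C@@]12O`) gives 43000 nM and compound 2 (`Cc1cccc(C2=NO[C@]3(C2)C(=O)O[C@@H]2[C@H]3CC[C@H](C)[C@]3(O)C=CC(=O)[C@@]23C)c1`) gives 15000 nM, the lower of the two numbers. Compound 3 (`C[C@H]1CC[C@@H]2[C@@H](OC(=O)[C@]23CC(c2ccc(C#N)cc2)=NO3)[C@]2(C)C(=O)C=C[C@@]12O`) carries 4-cyanophenyl in place of 3-methylphenyl on a carbon with a double bond to nitrogen. Going by the values given here, only one measured step bears on this place, and it is modest (a 2.9-fold lower number from compound 1 to compound 2 (0.46 log units; beyond the scatter)). It offers no guide to direction for a nitrile-bearing group. The step expected in this assay is therefore small (a 1.3-fold higher number from compound 2 to compound 3 (0.12 log units; within the scatter)), with no clear direction. Compound 3 is estimated at 20000 nM (expected range 8000 nM to 45000 nM).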

Compound 3, half-maximal inhibitory concentration: 53000 nM
Compound 3: the middle estimate sits 2.7-fold (0.42 log units) below what was measured; measured number outside the range, above it.
By their numbers in this assay, from the lowest: compound 2; then compounds 1 and 3 (each within the scatter of the next).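

In this assay, exchanging 3-methylphenyl for 4-cyanophenyl gives a 3.5-fold higher number from compound 2 to compound 3 (0.55 log units; beyond the scatter), so compound 2 is now separated beyond the scatter from both other aryl variants at this position. The other new comparison gives a 1.2-fold higher number from compound 1 to compound 3 (0.09 log units; within the scatter), which leaves 4-cyanophenyl and 2,6-dichlorophenyl unseparated despite their different substituents. Nothing available explains either result.

The exchange from compound 2 to compound 3 alters both the substituent and its ring location, and these two changes remain unseparated. From the compounds shown here alone, whether an aminomethyl or carboxylic acid group on the phenyl ring would track with compound 2 or with compound 1 and compound 3 remains open.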